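Branching the amide substituent on the shared core

The compounds below may be only part of what the source reports. "The series", "measured", "known", "first", "only" and "open" are said of these compounds alone.

Measured so far in a functional assay on the whole organism (strain Wistar) for inhibition, with Rattus norvegicus as the target, read by paw edema, with stated times of 60 min and 4 h, at a dose of 100 mg/kg by the oral route; a higher number here means more inhibition at the dose given (going by the name of the read-out), a lower number less inhibition:
compound 1 `CCN(CC)C(=O)CC1CCc2cc(OC)c(OC)cc21` gives 37.5%
compound 2 `CCCNC(=O)CC1CCc2cc(OC)c(OC)cc21` gives 26.6%

Among these two numbers compound 2 stands lowest, with compound 1 nearest and clearly higher. For the measured compounds named here, the one measured step, a number 10.9 percentage points lower from compound 1 to compound 2 (beyond the scatter), was modest but beyond the scatter. It concerns a change on the carbonyl carbon. Compound 3 `COc1cc2c(cc1OC)C(CC(=O)NC(C)C)CC2` has not been measured; it differs from compound 2 by isopropyl in place of propyl on an amide-type nitrogen. Going by the values given here, no measured step covers this change: the step between compound 1 and compound 2 alters a different substituent on the same nitrogen, so it only hints that substitution at this position can move the read-out modestly. For a rearrangement of the same atoms the expected shift is none beyond the scatter, so a number 0.4 percentage points higher from compound 2 to compound 3 (within the scatter) is taken as close to flat. Compound 3 is therefore estimated at 27%, ranging from 12% to 42%.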

Compound 3, a percentage reported as inhibition, in the whole organism at one dose (the size of the read-out at that dose, not a potency): 39.1%
Compound 3: middle estimate off by 12.1 percentage points, on the low side; the range from low to high includes it.
By their numbers in this assay, from the lowest: compound 2; then compounds 1 and 3 (each within the scatter of the next).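

In this assay the arrangement of the carbons on the amide-type nitrogen matters: isopropyl in place of propyl gives a number 12.5 percentage points higher from compound 2 to compound 3 (beyond the scatter), so a change that keeps the same atoms moves the read-out at this position. Isopropylamino in place of diethylamino on the carbonyl carbon gives a number 1.6 percentage points higher from compound 1 to compound 3 (within the scatter), so keeping the amide hydrogen does not by itself go with the low number of compound 2. Nothing measured here explains why the propyl and isopropyl amides differ.

The compounds shown leave open whether the gain seen with isopropyl extends to other branched groups on this nitrogen, such as tert-butyl, or to a ring such as cyclopropyl. They also leave open how a longer straight chain such as butyl would compare with propyl.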